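A One-Carbon Extension on a Methoxy Side Chain

The source may hold more compounds than are shown below. What is called first, only, known or untested is meant among the compounds shown, and "the series" means these compounds.

The series shares a core carrying a methyl group and an anilino substituent, and the compounds differ in the group attached at the remaining position. Compound 1 `COCc1nc2nc(C)cc(Nc3ccc(C(F)(F)F)cc3)n2n1` gives 13.3 mL.min-1.g-1 in an in vitro ADME assay on microsomes from liver (Mus musculus) for metabolic stability; a higher number here means faster removal of the compound, a lower number slower removal. Compound 2 `CCc1nc2nc(C)cc(Nc3cccc(Cl)c3)n2n1` gives 125 mL.min-1.g-1 in this assay, the higher of the two numbers, with compound 1 standing lowest; the gap between them is beyond the usual scatter. For compound 3 `Cc1cc(Nc2ccc(S(F)(F)(F)(F)F)cc2)n2nc(C(F)(F)F)nc2n1` this assay returns only a limit, < 6 mL.min-1.g-1, which is the limit of < 6 mL.min-1.g-1 in this assay, at which 1 of the 3 values shown sits.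

Compound 4 `COCCc1nc2nc(C)cc(Nc3ccc(C(F)(F)F)cc3)n2n1` has not yet been measured in this assay. It differs from compound 1 in one place: methoxymethyl in place of methoxy on a saturated chain carbon bound to an aromatic carbon. Among the measured compounds shown here, no pair of measured compounds differing in exactly one place is present in this set, so the size of this step cannot be read from a neighbour. Lengthening the side chain by one carbon is expected to shift clearance in this assay only slightly, toward a higher number, and most likely within the scatter of repeated measurements.

Compound 4 is therefore estimated at 20 mL.min-1.g-1, with a likely range from 8 mL.min-1.g-1 to 50 mL.min-1.g-1. The expected step from compound 1 is a 1.5-fold higher number from compound 1 to compound 4 (0.18 log units; within the scatter).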

Compound 4, intrinsic clearance in microsomes: 14.3 mL.min-1.g-1
The estimate for compound 4 lay 1.4-fold (0.15 log units) above the measured number; low and high end bracket the measured number.
By their numbers in this assay, from the lowest: compounds 1 and 4 (each within the scatter of the next); then compound 2. At a limit, below all of these: compound 3.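

In this assay, replacing methoxy with methoxymethyl on a saturated chain carbon bound to an aromatic carbon gives a 1.1-fold higher number from compound 1 to compound 4 (0.03 log units; within the scatter), so the two compounds cannot be told apart by this read-out. This is the first pair shown that differs in one place only, and it shows that, with the shared core and the anilino group held fixed, this one-carbon extension of the side chain leaves no readable mark on the clearance number. Nothing measured here bears on why the two compounds match.

From the compounds shown here alone, whether the same holds for a longer ether chain, or for a chain ending in an amine or a carboxylic acid instead of the methoxy group, remains open, as this single step covers only one added carbon on one chain. Compound 2 and compound 3 each differ from compound 1 in more than one place, so the contribution of the side chain cannot be separated from that of the substituent on the anilino ring.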